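This account rests on a few compounds, and the source may have more. Where it says the series, first, only, none or still open, it means among the compounds named here.

Measured in a functional assay on PC-3 cells (Homo sapiens) for cytotoxicity, read by MTT assay, with a stated time of 72 h; on this read-out higher numbers stand for weaker inhibition and lower numbers for stronger inhibition:
- compound 1, `COc1cc(-c2cncc(N[C@@H](C)c3ccccc3)n2)ccc1O`: 10000 nM
- compound 2, `CCC[C@H](Nc1cncc(-c2ccc(O)c(OC)c2)n1)c1ccccc1`: 160 nM
- compound 3, `CCCC(Nc1cncc(-c2ccc(O)c(OC)c2)n1)c1ccccc1`: 160 nM

Compound 3 shares its core with compound 2 and compound 1; the three differ only in the chain carbon that carries the phenyl group and in how that carbon is drawn. In this assay compound 3 stands level with compound 2 at the lowest of the three numbers, and well away from compound 1: a 63-fold lower number from compound 1 to compound 2 (1.80 log units; beyond the scatter), while no change at the digits printed from compound 2 to compound 3 (within the scatter), which fits (the fact that one of compounds 2 and 3 is drawn with a defined configuration and the other without, at the place where they differ).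

Compound 4, `CCCC(Nc1cncc(-c2ccc(O)c(OC)c2)n1)c1ccc(OC)cc1`, is not yet measured. It differs from compound 3 by methoxy in place of hydrogen on an aromatic carbon. Neither measured step touches the phenyl ring: one adds an ethyl to the chain, the other only changes how a stereocentre is drawn. Nothing measured here therefore tells how a methoxy on the phenyl ring will read, and the change is small in size. The expectation is a step of a 1.3-fold higher number from compound 3 to compound 4 (0.10 log units; within the scatter), not beyond the scatter, in no firm direction.

On that basis compound 4 is estimated at 200 nM in this assay, with a range from 60 nM to 700 nM.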

Compound 4, half-maximal inhibitory concentration: 3000 nM
Estimate against measurement, compound 4: 15-fold (1.18 log units) below, and the stated range ends below it.
By their numbers in this assay, from the lowest: compounds 2 and 3 (each within the scatter of the next); then compound 4; then compound 1.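

In this assay, the phenyl ring proves sensitive to change: replacing hydrogen with methoxy on an aromatic carbon, para to a large group, gives a 19-fold higher number from compound 3 to compound 4 (1.27 log units; beyond the scatter), which means clearly weaker inhibition of the cells. The earlier steps shown here concerned only the chain carbon that carries this ring, so they gave no view of the ring itself; this step shows that a single added methoxy can undo much of the gain seen when the chain was lengthened, though that gain was measured on a different pair of compounds. The compounds shown do not explain why this one change has so large an effect, and what is known about how compounds 2 and 3 are drawn has no bearing on it.

Going by these compounds, it remains open whether the loss belongs to methoxy itself or to any group at this place, since a fluorine, a hydroxy or an ethoxy there would each help to separate those readings. Also open, on these data alone, is how the same methoxy would read elsewhere on the ring, and whether a defined configuration at the chain carbon would matter in compound 4.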